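Trimming One Chlorine from an Aryl Urea

The source may hold more compounds than are shown below. What is called first, only, known or untested is meant among the compounds shown, and "the series" means these compounds.

Compound 1, `O=C(Nc1cccc(CNc2nccnc2Cl)c1)NC1CCCC1`, in a functional assay on MGC-803 cells (Homo sapiens) for antiproliferative activity, read by MTT assay, with a stated time of 48 h (a higher number here means a weaker inhibitor, a lower number a stronger inhibitor), gives 23400 nM.
Compound 2, `O=C(Nc1cccc(CNc2nccnc2Cl)c1)Nc1ccc(Cl)cc1Cl`, in this assay gives 6430 nM.

For the measured compounds named here, of the two numbers so far, compound 2 holds the lower one; the change from compound 1 brings a 3.6-fold lower number from compound 1 to compound 2 (0.56 log units; beyond the scatter), a modest step that comes from putting 2,4-dichlorophenyl in place of cyclopentyl on an amide-type nitrogen. Compound 3, `O=C(Nc1cccc(CNc2nccnc2Cl)c1)Nc1ccccc1Cl`, keeps the shared core and the aryl urea but differs from compound 2 by hydrogen in place of chloro on an aromatic carbon.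

Going by the values given here, no measured step speaks directly to this change: the only step available compares a ring with a chain, not one substituted ring with another. That step bears on compound 3 only in so far as the aryl urea itself is retained. Compound 3 is therefore expected to sit close to compound 2, with a 1.4-fold higher number from compound 2 to compound 3 (0.15 log units; within the scatter), perhaps a little weaker, and the estimate for compound 3 in this assay is 9000 nM, spanning 3500 nM to 25000 nM.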

Compound 3, half-maximal inhibitory concentration: 7130 nM
Estimate against measurement, compound 3: 1.3-fold (0.10 log units) above, and the stated range covers the measured number.
By their numbers in this assay, from the lowest: compounds 2 and 3 (each within the scatter of the next); then compound 1.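

In this assay, replacing the chloro para to a large group with hydrogen, which turns 2,4-dichlorophenyl into 2-chlorophenyl, gives a 1.1-fold higher number from compound 2 to compound 3 (0.04 log units; within the scatter), so this chloro makes no difference that the assay can resolve. The advantage over cyclopentyl holds with a single chlorine on the ring: 2-chlorophenyl in place of cyclopentyl gives a 3.3-fold lower number from compound 1 to compound 3 (0.52 log units; beyond the scatter), and so both aryl ureas shown carry lower numbers than compound 1. Nothing available explains why the second chlorine can go without a visible effect on the number.

On these data alone, what a plain phenyl with no chloro at all would give remains open. As far as these compounds go, it is also open whether a methoxy group or an amine on the carbon that lost its chloro would move the number in this assay.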